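From Dipropylamino to Dipentylamino on a Shared Core

The source may hold more compounds than are shown below. What is called first, only, known or untested is meant among the compounds shown, and "the series" means these compounds.

Measured in a physicochemical assay for lipophilicity, read by HPLC, at pH 7.5; on this read-out higher numbers stand for higher lipophilicity and lower numbers for lower lipophilicity:
Compound 1 `CCc1cc(CC)n2nc(-c3ccc(OC)cc3)c(CC(=O)N(C)C)c2n1` gives 2.47
Compound 2 `CCCN(CCC)C(=O)Cc1c(-c2ccc(OC)cc2)nn2c(CC)cc(CC)nc12` gives 3.35

Of these two, compound 2 stands highest, and the gap to compound 1 lies beyond the scatter. Compound 3 `CCCCCN(CCCCC)C(=O)Cc1c(-c2ccc(OC)cc2)nn2c(CC)cc(CC)nc12` has not yet been measured. The structural change from compound 2 is this: dipentylamino in place of dipropylamino on a carbonyl carbon. Among the compounds with values here, one measured step bears on it, and it sits at the same place: a number 0.88 log units higher from compound 1 to compound 2 (beyond the scatter) when dipropylamino replaced dimethylamino on a carbonyl carbon. A single step shows no trend, so the size remains uncertain, but a rise of similar size is expected here. The expected step is a number 0.95 log units higher from compound 2 to compound 3 (beyond the scatter) in the same direction as that measured one. Compound 3 is therefore estimated at 4.3 in this assay (range 3.8 to 4.9).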

Compound 3, partition coefficient: 4.29
For compound 3 the middle estimate is 0.01 log units above the measured one; low and high end bracket the measured number.
By their numbers in this assay, from the lowest: compound 1; then compound 2; then compound 3.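

In this assay the change on the carbonyl carbon to dipentylamino, with 11 heavy atoms against 7 for dipropylamino, gives a number 0.94 log units higher from compound 2 to compound 3 (beyond the scatter) and so shows that the rise at this position did not end with dipropylamino. Over the full change from dimethylamino to dipentylamino the result is a number 1.82 log units higher from compound 1 to compound 3 (beyond the scatter) and the numbers follow the order of the chains on the amide nitrogen, with no compound shown going against that order. No measurement given here points to an explanation for this rise.

Three compounds on one core leave open whether the rise carries on with a longer chain such as dioctylamino. They also leave open what a ring amine such as piperidine or a branched group such as diisopropylamino would do at this carbonyl carbon.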